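The compounds below may be only part of what the source reports. "The series", "measured", "known", "first", "only" and "open" are said of these compounds alone.

In a functional assay on OVCAR-3 cells (Homo sapiens) for inhibition, read by MTT assay, with a stated time of 24 h (a lower number here means a stronger inhibitor, a higher number a weaker inhibitor), compound 3 (`COc1ccccc1-n1cc(CN2C(=O)C[C@@H]3CC[C@@]2(C)C3(C)C)nn1`) gives 140 nM while compound 2 (`CC1(C)[C@H]2CC[C@]1(C)N(Cc1cn(-c3cccc(C#N)c3)nn1)C(=O)C2`) gives 230 nM and compound 1 (`CC1(C)[C@H]2CC[C@]1(C)N(Cc1cn(-c3ccc(C#N)cc3)nn1)C(=O)C2`) gives 380 nM on the same scale. The data show a 2.7-fold lower number from compound 1 to compound 3 (0.43 log units; beyond the scatter) as the one clear gap and a 1.6-fold lower number from compound 2 to compound 3 (0.22 log units; within the scatter) as no clear gap. Among the compounds with values here, compound 4 (`CC1(C)[C@H]2CC[C@]1(C)N(Cc1cn(-c3ccc(Br)cc3)nn1)C(=O)C2`) brings 4-bromophenyl in place of 2-methoxyphenyl on an aromatic nitrogen and no bromine-bearing compound has been measured. Compound 1 carries 4-cyanophenyl at that place, so a 2.7-fold lower number from compound 1 to compound 3 (0.43 log units; beyond the scatter) is the nearest guide and, read in reverse, points to a modest rise. The expected move in this assay is of similar size, with a 2.1-fold higher number from compound 3 to compound 4 (0.33 log units; beyond the scatter) as the estimate. Compound 4 is expected at 300 nM (estimated range 110 nM to 750 nM).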

Compound 4, half-maximal inhibitory concentration: 140 nM
Compound 4: middle estimate off by 2.1-fold (0.33 log units), on the high side; measured number inside the range.
By their numbers in this assay, from the lowest: compounds 3, 4, 2 and 1 (each within the scatter of the next, the first and the last beyond it).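

In this assay the step to 4-bromophenyl gives no change at the digits printed from compound 3 to compound 4 (within the scatter) and so cannot be told apart from 2-methoxyphenyl at this position. Against the 3-cyanophenyl compound, a 1.6-fold lower number from compound 2 to compound 4 (0.22 log units; within the scatter) shows no clear gap either. With the group's place held the same, bromo in place of cyano gives a 2.7-fold lower number from compound 1 to compound 4 (0.43 log units; beyond the scatter) and thus reaches the same clear gap from compound 1 that 2-methoxyphenyl reached, so that gap does not depend on a methoxy group. The compounds shown leave open whether an amine or a carboxylic acid on this phenyl ring would keep the number in this range. No evidence is available that accounts for these values.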